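A trifluoromethyl capping the chain of a weak activator

The source may report more compounds than this note shows. Statements on the series, on what has been measured and on what is new or still open speak of the compounds shown alone.

Two measured compounds frame this step. Compound 1 `COC(=O)N(C)c1c(N)nc(-n2nc(Cc3ccccc3F)c3cc(F)ccc32)nc1N` gives 960 nM in an assay on CHO cells for activation of soluble guanylate cyclase alpha1/beta1 complex (Homo sapiens), read by cGMP accumulation; on this read-out lower numbers stand for an effect already at smaller amounts and higher numbers for an effect only at larger amounts of compound. Compound 2 `CCCc1nn(-c2nc(N)c3c(n2)NC(=O)C3(C)C)c2ccc(Cl)cc12` gives 546000 nM in this assay, the highest number of the two, and it stands far from compound 1, a gap well beyond the usual scatter. Compound 3 `CC1(C)C(=O)Nc2nc(-n3nc(CCCC(F)(F)F)c4cc(Cl)ccc43)nc(N)c21` has not yet been measured; it differs from compound 2 by trifluoromethyl in place of hydrogen on a saturated chain carbon, three bonds along the chain from an aromatic carbon, so that the propyl chain of compound 2 becomes a 4,4,4-trifluorobutyl chain in compound 3. Among the measured compounds shown here, no pair of measured compounds shows the effect of this single change, and compound 1 differs from compound 2 in too many places to guide it. The step from compound 2 to compound 3 is therefore expected to be modest, with a slight lean toward a lower number, as a 2.2-fold lower number from compound 2 to compound 3 (0.34 log units; beyond the scatter). Compound 3 is estimated at 250000 nM, within a range from 40000 nM to 1200000 nM.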

Compound 3, half-maximal effective concentration: 117000 nM
Compound 3: middle estimate off by 2.1-fold (0.33 log units), on the high side; low and high end bracket the measured number.
By their numbers in this assay, from the lowest: compound 1; then compound 3; then compound 2.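

Capping the propyl chain with trifluoromethyl, on a saturated chain carbon three bonds along the chain from an aromatic carbon, gives a 4.7-fold lower number from compound 2 to compound 3 (0.67 log units; beyond the scatter) in this assay. This shows that the chain position responds to a change in its outer end, and that the larger 4,4,4-trifluorobutyl chain does not raise the number here. Nothing measured in this set gives a reason for the shift.

From the compounds shown here alone, whether the fluorine atoms or the added chain length carry the step stays open, and a plain butyl chain would separate the two. Also open, going by these compounds, is how an amine or a carboxylic acid at the end of this chain, or a still longer chain, would read in this assay, and whether the same change would act alike on the core of compound 1.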